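The source may hold more compounds than are shown below. What is called first, only, known or untested is meant among the compounds shown, and "the series" means these compounds.

Compound 1 `COc1ccc(-n2ccc(=O)c(C(=O)Nc3ccc(Oc4ccnc5[nH]ccc45)cc3)n2)cc1` and compound 2 `O=C(Nc1ccc(Oc2ccnc3[nH]ccc23)cc1)c1nn(-c2ccc(Br)cc2)ccc1=O` share one core and differ only in a single group. In a functional assay on PC-3 cells (Homo sapiens) for cytotoxicity, read by MTT assay, with a stated time of 72 h (on this read-out lower numbers stand for stronger inhibition and higher numbers for weaker inhibition), compound 1 reaches only the limit of the assay, > 60000 nM, and gives no number. In this assay compound 2 gives 8040 nM. The change between them, (bromo in place of methoxy on an aromatic carbon), made a step of an at least 7.4-fold lower number from compound 1 to compound 2 (0.87 log units; beyond the scatter); its size is known only as a minimum because of the limit of > 60000 nM in this assay, at which 2 of the 3 values shown sit.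

Compound 3 `COc1ccc(-n2ccc(=O)c(C(=O)Nc3ccc(Oc4ccnc5c4ccn5C)c(F)c3)n2)cc1` is built on a second core. How this core differs from the core of compound 1 is not broken down here. In this assay compound 3 also sits at the limit of the assay, > 60000 nM, without a number.

Compound 4 `Cn1ccc2c(Oc3ccc(NC(=O)c4nn(-c5ccc(Br)cc5)ccc4=O)cc3F)ccnc21` carries the same change on the second core, (bromo in place of methoxy on an aromatic carbon), with the place described in the same words as before. On the second core the step from compound 3 to compound 4 is expected to be about an at least 5.0-fold lower number from compound 3 to compound 4 (0.69 log units; beyond the scatter), resting on the change from compound 1 to compound 2 with its an at least 7.4-fold lower number from compound 1 to compound 2 (0.87 log units; beyond the scatter). For compound 4 in this assay a value near 12000 nM is estimated, between 3000 nM and 60000 nM.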

Compound 4, half-maximal inhibitory concentration: > 60000 nM
Compound 4: only a limit was reported (the forecaster's own chance of this, stated with the estimate: 25%); middle value at least 5.0-fold (0.69 log units) from the limit.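

Compound 3 and compound 4 both stand only as limits in this assay, and the step between them cannot be read because neither gives a number: the limit of > 60000 nM in this assay, at which 3 of the 4 values shown sit.

The compounds shown leave open whether bromo in place of methoxy lowers the number on the second core, as it does on the core of compound 1.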